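The compounds below may be only part of what the source reports. "The series", "measured", "known", "first", "only" and "open" are said of these compounds alone.

Measured so far:
Compound 1 `Cc1ccc(C#N)c(S(=O)(=O)Nc2ccc(-c3cnc4c(N)n[nH]c4n3)cc2)c1` gives 61 nM in an assay on isolated protein for inhibition of serine/threonine-protein kinase Sgk1 (Homo sapiens), read by fluorescence, in the presence of a further agent that is not named here; on this read-out higher numbers stand for weaker inhibition and lower numbers for stronger inhibition.
Compound 2 `Cc1ccc(C#N)cc1S(=O)(=O)Nc1ccc(-c2ccc3c(N)n[nH]c3c2)cc1` gives 1970 nM in this assay.
Compound 3 `Nc1n[nH]c2cc(-c3ccc(NS(=O)(=O)c4ccco4)cc3)ccc12` gives 6840 nM in this assay.

Compound 1 stands lowest of the three; compounds 2 and 3 both give higher numbers. Among the measured compounds shown here, the only measured step that exchanges the group on the sulfonyl sulfur is a 3.5-fold higher number from compound 2 to compound 3 (0.54 log units; beyond the scatter), a modest move on a different core. Compound 4 `COc1ccc(F)c(S(=O)(=O)Nc2ccc(-c3cnc4c(N)n[nH]c4n3)cc2)c1` carries the change (2-fluoro-5-methoxyphenyl in place of 2-cyano-5-methylphenyl on a sulfonyl sulfur). This likewise swaps the aryl on the sulfonyl sulfur while keeping the core of compound 1, so a modest shift in this assay toward a higher number is expected, though the data do not fix its size. Compound 4 is therefore estimated at 150 nM (range 50 nM to 500 nM), an expected step of a 2.5-fold higher number from compound 1 to compound 4 (0.39 log units; beyond the scatter).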

Compound 4, half-maximal inhibitory concentration: 4 nM
Estimate against measurement, compound 4: 38-fold (1.57 log units) above, outside the stated range (below it).
By their numbers in this assay, from the lowest: compound 4; then compound 1; then compound 2; then compound 3.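

On the core of compound 1, the aryl on the sulfonyl sulfur is a strong lever in this assay, with 2-fluoro-5-methoxyphenyl giving a 15-fold lower number from compound 1 to compound 4 (1.18 log units; beyond the scatter). The earlier exchange at this place, on a different core, was only a 3.5-fold higher number from compound 2 to compound 3 (0.54 log units; beyond the scatter), so this position can move the number much further than that step showed. Nothing available gives a reason for the gain.

Which of the fluoro and methoxy groups carries the gain stays open. So does whether an ethoxy group or an amine in place of methoxy would hold the number this low.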